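The source may report more compounds than this note shows. Statements on the series, on what has been measured and on what is new or still open speak of the compounds shown alone.

Compound 1 `COc1ccc(C2OC(c3ccc4ccccc4c3)=NN2C(C)=O)cc1` in a functional assay on B16-F10 cells (Mus musculus) for antiproliferative activity, read by MTT assay, with a stated time of 48 h (on this read-out higher numbers stand for weaker inhibition and lower numbers for stronger inhibition), gives 6.86 ug/mL. Compound 2 `CC(=O)N1N=C(c2ccc3ccccc3c2)OC1c1ccccc1Br` gives 6.98 ug/mL, and compound 3 `CC(=O)N1N=C(c2ccc3ccccc3c2)OC1c1ccccc1F` gives 6.05 ug/mL. Among the compounds with values here, on these three numbers compound 1 stands second highest, nearest to compound 2 and furthest from compound 3, yet a 1.0-fold higher number from compound 1 to compound 2 (0.01 log units; within the scatter) and a 1.1-fold lower number from compound 1 to compound 3 (0.05 log units; within the scatter) both lie within the scatter, as does a 1.2-fold lower number from compound 2 to compound 3 (0.06 log units; within the scatter); the series so far is flat.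

The next compound, compound 4 `CC(=O)N1N=C(c2ccc3ccccc3c2)OC1c1ccc([N+](=O)[O-])cc1`, differs from compound 1 by nitro in place of methoxy on an aromatic carbon. Within the data shown here, no measured pair speaks directly to nitro in place of methoxy. Among the measured compounds shown here, the steps that bear on it are a 1.0-fold higher number from compound 1 to compound 2 (0.01 log units; within the scatter) and a 1.1-fold lower number from compound 1 to compound 3 (0.05 log units; within the scatter), which also replace the 4-methoxyphenyl of compound 1 and produced no movement beyond the scatter. On that basis the expectation for compound 4 in this assay is no step beyond the scatter, a 1.1-fold lower number from compound 1 to compound 4 (0.02 log units; within the scatter). The estimate for compound 4 is 6.5 ug/mL, with a range from 3.5 ug/mL to 13 ug/mL.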

Compound 4, half-maximal inhibitory concentration: 9.32 ug/mL
Estimate against measurement, compound 4: 1.4-fold (0.16 log units) below, and the stated range covers the measured number.
By their numbers in this assay, from the lowest: compounds 3, 1, 2 and 4 (each within the scatter of the next).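

In this assay, within the data shown here, nitro in place of methoxy on an aromatic carbon, para to a large group, stays within the scatter (a 1.4-fold higher number from compound 1 to compound 4 (0.13 log units; within the scatter)), so this change at this position gives no step that can be told from repeat measurement. Among these compounds, the 4-nitrophenyl compound also stays within the scatter of the two halogen-bearing compounds (a 1.5-fold higher number from compound 3 to compound 4 (0.19 log units; within the scatter); a 1.3-fold higher number from compound 2 to compound 4 (0.13 log units; within the scatter)), which extends the flat picture to a nitro group, a substituent the earlier compounds did not carry. Nothing measured accounts for how close these numbers lie.

Still open, as far as these compounds go, is whether an amine, a carboxylic acid or a longer alkoxy chain at this same place would give a step beyond the scatter. The compounds shown also leave open whether changes elsewhere on the shared core would move the number at all.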